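A few compounds are considered here, and "the series" means these few. Any claim that something is new, unique, unknown or untested is made for them only; others in the source may bear on it.

Compound 1, `Fc1ccccc1CSc1nnc(-c2cnccn2)o1`, is the reference point of this small set: in a functional assay on BGC-823 cells (Homo sapiens) for antiproliferative activity, read by MTT assay, with a stated time of 48 h (on this read-out lower numbers stand for stronger inhibition and higher numbers for weaker inhibition), compound 1 gives 18200 nM. Compound 2, `Clc1ccccc1CSc1nnc(-c2cnccn2)o1`, differs from it by one change, (chloro in place of fluoro on an aromatic carbon); in this assay compound 2 gives 27700 nM, and the measured step is a 1.5-fold higher number from compound 1 to compound 2 (0.18 log units; within the scatter). Compound 3, `Fc1ccc(CSc2nnc(-c3cnccn3)s2)cc1`, carries a different core; the difference between the two cores is not broken down here. In this assay compound 3 gives 29300 nM, which lies within the scatter of both compound 1 and compound 2, so no order among the three can be read from these numbers.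

Compound 4, `Clc1ccc(CSc2nnc(-c3cnccn3)s2)cc1`, is not yet measured. It differs from compound 3 by chloro in place of fluoro on an aromatic carbon. Going by the values given here, this is the same kind of change as the one from compound 1 to compound 2, but not the same: there the place was ortho to a large group, here it is para to a large group, and the core also differs. Resting on the step seen in a 1.5-fold higher number from compound 1 to compound 2 (0.18 log units; within the scatter), the step from compound 3 to compound 4 is expected to be a 1.2-fold higher number from compound 3 to compound 4 (0.09 log units; within the scatter). The value for compound 4 in this assay is estimated at 36000 nM, with a likely range from 15000 nM to 85000 nM.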

Compound 4, half-maximal inhibitory concentration: 13400 nM
For compound 4 the middle estimate is 2.7-fold (0.43 log units) above the measured one; measured number below the stated range.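

In this assay, chloro in place of fluoro gives a 2.2-fold lower number from compound 3 to compound 4 (0.34 log units; beyond the scatter), while the same exchange on the core of compound 1 gives a 1.5-fold higher number from compound 1 to compound 2 (0.18 log units; within the scatter). The two steps do not agree, so in this series the change cannot be carried from one core to the other as a fixed step: the same change on two cores in this assay, a 1.5-fold higher number (0.18 log units; within the scatter) from compound 1 to compound 2 and a 2.2-fold lower number (0.34 log units; beyond the scatter) from compound 3 to compound 4, 3.3-fold (0.52 log units) apart, beyond the scatter of two such steps

This does not show that the core alone sets the difference: the halogen also stands at a different place on the ring in the two pairs, and each step rests on a single pair of compounds. The compounds shown leave open whether the two cores would respond alike with the halogen at one and the same place on the ring. They also leave open what a methoxy group, an amine or a carboxylic acid would do in place of the halogen.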